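This account rests on a few compounds, and the source may have more. Where it says the series, first, only, none or still open, it means among the compounds named here.

Measured in a functional assay on A2780 cells (Homo sapiens) for antiproliferative activity, read by resazurin assay, with a stated time of 72 h; a higher number here means a weaker inhibitor, a lower number a stronger inhibitor:
- Compound 1 `CN(Cc1cccc(F)c1)C(=O)c1cc2c(Cc3ccccc3)n[nH]c2cc1O`: 5000 nM
- Compound 2 `Cc1cccc(Cc2n[nH]c3cc(O)c(C(=O)NCc4ccccc4)cc23)c1`: > 10000 nM, a limit of the assay
- Compound 3 `Cc1cccc(Cc2n[nH]c3cc(O)c(C(=O)N(C)Cc4cccc(F)c4)cc23)c1`: 440 nM

Among these, compound 3 has the lowest number, 440 nM. Compound 4 `COc1ccc(CN(C)C(=O)c2cc3c(Cc4cccc(C)c4)n[nH]c3cc2O)cc1OC` carries 3,4-dimethoxyphenyl in place of 3-fluorophenyl on a saturated chain carbon bound to an amide-type nitrogen. The step of an at least 22-fold lower number from compound 2 to compound 3 (1.35 log units; beyond the scatter) changes this same amide substituent, but it alters more than the aromatic ring. The step of an 11-fold lower number from compound 1 to compound 3 (1.06 log units; beyond the scatter) lies elsewhere on the molecule. Neither isolates the present change, so only a modest rise in this assay is anticipated. The expected step is a 1.8-fold higher number from compound 3 to compound 4 (0.26 log units; within the scatter). Compound 4 is estimated at 800 nM, with an expected range of 200 nM to 3000 nM.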

Compound 4, half-maximal inhibitory concentration: 3700 nM
Beside the measured number, compound 4's estimate is 4.6-fold (0.67 log units) below it; the whole stated range lies below it.
By their numbers in this assay, from the lowest: compound 3; then compounds 4 and 1 (each within the scatter of the next). At a limit, above all of these: compound 2.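

In this assay, 3,4-dimethoxyphenyl in place of 3-fluorophenyl on a saturated chain carbon bound to an amide-type nitrogen gives an 8.4-fold higher number from compound 3 to compound 4 (0.92 log units; beyond the scatter). Unlike the earlier steps, this one changes only the aromatic ring of the amide substituent, so that ring alone moves the number beyond the scatter. Nothing measured here accounts for the size of this step. On these data alone, whether a single methoxy group would give the same step stays open. So does how a pyridine ring or a carboxylic acid in place of 3-fluorophenyl would read in this assay.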